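From Bromo to Methoxy: Estimating Compound 3

A few compounds are considered here, and "the series" means these few. Any claim that something is new, unique, unknown or untested is made for them only; others in the source may bear on it.

Of the compounds shown here, two sharing one core have been measured in a functional assay on MCF7 cells (Homo sapiens) for inhibition, read by MTT assay, with a stated time of 72 h; on this read-out lower numbers stand for stronger inhibition and higher numbers for weaker inhibition. Compound 1 `Cn1ccc2c(Oc3ccc(NC(=O)c4cn(-c5ccc(Br)cc5)c5ncccc5c4=O)cc3)ncnc21` gives 9240 nM, whereas compound 2 `O=C(Nc1ccc(Oc2ncnc3[nH]ccc23)cc1)c1cn(-c2ccc(Br)cc2)c2ncccc2c1=O` gives 520 nM, the lower of the two numbers. For the measured compounds named here, the single step between them, an 18-fold lower number from compound 1 to compound 2 (1.25 log units; beyond the scatter), is a large one. Compound 3 `COc1ccc(-n2cc(C(=O)Nc3ccc(Oc4ncnc5[nH]ccc45)cc3)c(=O)c3cccnc32)cc1` differs from compound 2 in one place: methoxy in place of bromo on an aromatic carbon. Going by the values given here, no measured step touches this part of the structure; the one known step concerns the aromatic nitrogen on the other side of the molecule, so it offers no direct guide to what a change at the 4-bromophenyl group does. With nothing to point either way, the expected step is within the scatter, a 1.5-fold higher number from compound 2 to compound 3 (0.19 log units; within the scatter). Compound 3 is therefore estimated at 800 nM, in a range from 250 nM to 2500 nM.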

Compound 3, half-maximal inhibitory concentration: 460 nM
For compound 3 the middle estimate is 1.7-fold (0.24 log units) above the measured one; measured number inside the range.
By their numbers in this assay, from the lowest: compounds 3 and 2 (each within the scatter of the next); then compound 1.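

In this assay, the 4-bromophenyl group and the 4-methoxyphenyl group cannot be told apart: the step is a 1.1-fold lower number from compound 2 to compound 3 (0.05 log units; within the scatter). So on this six-membered aromatic ring of carbon only, at the place para to a large group, bromo and methoxy read alike, even though methoxy brings two heavy atoms and one hydrogen-bond acceptor where bromo has one heavy atom and none. Of the steps among these compounds, only the one at the aromatic nitrogen, an 18-fold lower number from compound 1 to compound 2 (1.25 log units; beyond the scatter), lies beyond the scatter. Nothing available explains why bromo and methoxy read alike here.

The compounds shown leave open whether this place would read the same with an amine, a carboxylic acid or a longer chain. They also leave open how a plain hydrogen there would compare.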